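A few compounds are considered here, and "the series" means these few. Any claim that something is new, unique, unknown or untested is made for them only; others in the source may bear on it.

Measured compounds: compound 1 `Oc1ccc(/C=C2\CCN=C2c2cccnc2)c(O)c1` gives 120 nM in an assay for displacement of a labelled ligand from Nicotinic acetylcholine receptor alpha8 subunit (Periplaneta americana), read by scintillation counting, with a stated time of 2 h, at 24 degrees C; on this read-out higher numbers stand for weaker inhibition and lower numbers for stronger inhibition; compound 2 `Oc1ccc(/C=C2\CCN=C2c2cccnc2)cc1` gives 310 nM; compound 3 `COc1cccc(/C=C2\CCN=C2c2cccnc2)c1` gives > 10000 nM.

The value for compound 3 is a limit of this assay and not a number (the limit of > 10000 nM in this assay, at which 1 of the 3 values shown sits). Among the two numbers shown, compound 2 holds the higher one, and its nearest neighbour is compound 1, the step of a 2.6-fold higher number from compound 1 to compound 2 (0.41 log units; beyond the scatter) lying beyond the scatter. Compound 4 `CN(C)c1ccc(/C=C2\CCN=C2c2cccnc2)cc1` has not yet been measured in this assay. It differs from compound 2 by dimethylamino in place of hydroxy on an aromatic carbon. Among the compounds with values here, the only measured step that bears on this change is a 2.6-fold higher number from compound 1 to compound 2 (0.41 log units; beyond the scatter), where the loss of a hydroxy on an aromatic carbon raised the number modestly. The change to compound 4 also removes a hydroxy, this time para to a large group, and puts a dimethylamino in its place, a group that keeps one hydrogen-bond acceptor but carries no hydrogen-bond donor. Within the data shown here, no measured pair shows what a dimethylamino at this place does, so the estimate carries wide uncertainty. On the evidence of a 2.6-fold higher number from compound 1 to compound 2 (0.41 log units; beyond the scatter), compound 4 is expected to give a higher number than compound 2, a step of about a 4.8-fold higher number from compound 2 to compound 4 (0.68 log units; beyond the scatter). Compound 4 is therefore estimated at 1500 nM, within a range of 300 nM to 10000 nM.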

Compound 4, half-maximal inhibitory concentration: 5490 nM
Compound 4: middle estimate off by 3.7-fold (0.56 log units), on the low side; the range from low to high includes it.
By their numbers in this assay, from the lowest: compound 1; then compound 2; then compound 4. At a limit, above all of these: compound 3.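

At the place para to a large group, dimethylamino in place of hydroxy gives an 18-fold higher number from compound 2 to compound 4 (1.25 log units; beyond the scatter), a larger step than a 2.6-fold higher number from compound 1 to compound 2 (0.41 log units; beyond the scatter), which came from hydrogen in place of hydroxy at another place on the ring. The earlier compounds shown here showed only that losing a hydroxy raises the number modestly; this result shows that the hydroxy at this place cannot be exchanged for dimethylamino in this assay without a large rise, although compound 4 still gives a number and not a limit. The exchange removes a hydrogen-bond donor, keeps a hydrogen-bond acceptor and adds heavy atoms all at once, and no measurement shown gives a reason for the size of this step.

The compounds shown leave open whether the rise follows the lost donor or the added atoms, a question that an amino, a methylamino or a methoxy at this same place would help to separate. They also leave open whether dimethylamino would cost as much with the second hydroxy of compound 1 still on the ring.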